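From compound 2 to compound 3: one side group exchanged

The source may report more compounds than this note shows. Statements on the series, on what has been measured and on what is new or still open speak of the compounds shown alone.

Compound 1 `C=CS(=O)(=O)NC/C=C/c1cc(OC)cc(O)c1C(=O)OCC(C)c1ccccc1`: 9.5%
Compound 2 `COc1cc(O)c(C(=O)OCC(C)c2ccccc2)c(/C=C/CN2C(=O)C=CC2=O)c1`: 56%

In a functional assay on HL-60 cells (Homo sapiens) for inhibition, read by luminescence, with a stated time of 72 h, tested at 5 uM (a lower number here means less inhibition of growth, a higher number more inhibition of growth at the concentration tested), compound 2 gives 56%, the higher of the two numbers, and compound 1 gives 9.5%. The next structure, compound 3 `COc1cc(O)c(C(=O)OCC2CCCCC2)c(/C=C/CN2C(=O)C=CC2=O)c1`, differs from compound 2 in one place: cyclohexyl in place of 1-phenylethyl on a saturated chain carbon bound to an oxygen next to a carbonyl group. In both cases the group holds a six-membered ring of carbon only, aromatic in the group that leaves and non-aromatic in the one that enters. For the measured compounds named here, the only measured step, a number 46.5 percentage points higher from compound 1 to compound 2 (beyond the scatter), was large, but it lies at another place, on a saturated chain carbon bound to a double-bonded chain carbon. It therefore says little about this exchange. Going by the values given here, with no measured step at this place, the expectation starts from compound 2 at 56%, and no change beyond the scatter is expected. The expected step is a number 4 percentage points lower from compound 2 to compound 3 (within the scatter). For compound 3 the estimated value is 52%, with an expected range from 27% to 77%.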

Compound 3, percent growth inhibition at one concentration: 71%
For compound 3 the middle estimate is 19 percentage points below the measured one; the range from low to high includes it.
By their numbers in this assay, from the lowest: compound 1; then compound 2; then compound 3.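

At the place on a saturated chain carbon bound to an oxygen next to a carbonyl group, the side group can be changed without losing growth inhibition. In this assay, cyclohexyl in place of 1-phenylethyl gives a number 15 percentage points higher from compound 2 to compound 3 (beyond the scatter) and so, in this one pair, a non-aromatic ring of carbon only serves at least as well as an aromatic one. No measurement at hand accounts for this rise.

The two groups differ both in the kind of ring and in size, and this single pair cannot separate those two differences. Going by these compounds, it also remains open how this place responds to groups of another kind, such as a longer open carbon chain, an amine or a carboxylic acid.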